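From Phenyl to Methyl at the Top of the Series

The compounds below may be only part of what the source reports. "The series", "measured", "known", "first", "only" and "open" are said of these compounds alone.

Compound 2 `CS(=O)(=O)c1ccc(Cc2nnc3n2N=C(c2ccc(-c4ccccc4)cc2)CS3)cc1` stands highest of the three compounds measured in a functional assay on HT-29 cells (Homo sapiens) for cytotoxicity, read by MTT assay, with a stated time of 48 h, tested at 50 uM (on this read-out higher numbers stand for a stronger effect at the one concentration tested and lower numbers for a weaker effect), where compound 2 gives 67.9%. Compound 1 `CS(=O)(=O)c1ccc(Cc2nnc3n2N=C(c2ccccc2)CS3)cc1` gives 46.7% and compound 3 `CS(=O)(=O)c1ccc(Cc2nnc3n2N=C(c2ccc(Cl)cc2Cl)CS3)cc1` gives 27.3%. The step of a number 21.2 percentage points higher from compound 1 to compound 2 (beyond the scatter) came with phenyl in place of hydrogen on an aromatic carbon, while a number 19.4 percentage points lower from compound 1 to compound 3 (beyond the scatter) came with 2,4-dichlorophenyl in place of phenyl on a carbon with a double bond to nitrogen. Compound 4 `Cc1ccc(C2=Nn3c(Cc4ccc(S(C)(=O)=O)cc4)nnc3SC2)cc1` differs from compound 2 by methyl in place of phenyl on an aromatic carbon. Going by the values given here, this change partly reverses the one behind a number 21.2 percentage points higher from compound 1 to compound 2 (beyond the scatter), so a drop is expected, though smaller than that gain. Compound 4 is therefore estimated at 53%, in a range from 38% to 67%, which means an expected a number 14.9 percentage points lower from compound 2 to compound 4 (beyond the scatter).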

Compound 4, a percentage reported as activity, at one concentration (the size of the read-out at that concentration, not a potency): 37.9%
Compound 4: the middle estimate sits 15.1 percentage points above what was measured; measured number below the stated range.
By their numbers in this assay, from the lowest: compound 3; then compounds 4 and 1 (each within the scatter of the next); then compound 2.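

In this assay, methyl on an aromatic carbon, para to a large group, does not hold the gain seen with phenyl (a number 30 percentage points lower from compound 2 to compound 4 (beyond the scatter)), and against hydrogen at this place it shows no difference beyond the scatter (a number 8.8 percentage points lower from compound 1 to compound 4 (within the scatter)). Of these three groups, only phenyl stands clear of hydrogen here. Swapping 2,4-dichlorophenyl for 4-methylphenyl still leaves a gap beyond the scatter (a number 10.6 percentage points higher from compound 3 to compound 4 (beyond the scatter)). As far as these compounds go, whether a methoxy group, an amine or a carboxylic acid here would follow methyl or phenyl stays open. Nothing available explains these steps.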